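The source may hold more compounds than are shown below. What is called first, only, known or untested is meant among the compounds shown, and "the series" means these compounds.

Measured so far:
Compound 1 `Nc1ccc(Nc2c(C(=O)NCc3ccc(F)cc3)nc(Br)c3cccnc23)cc1` gives 7000 nM in a functional assay on MDA-MB-435 cells (Homo sapiens) for cytotoxicity, read by MTT assay, with a stated time of 72 h; a lower number here means a stronger inhibitor, a higher number a weaker inhibitor.
Compound 2 `C[C@H](NC(=O)c1nc(Br)c2cccnc2c1N[C@H]1CC[C@H](N)CC1)c1ccc(F)cc1` reaches only the limit > 10000 nM in this assay, a limit rather than a number.
Compound 3 `O=CNCCCCCCNc1nc(C(=O)NCc2ccc(F)cc2)c(O)c2ncccc12` gives 16000 nM in this assay.

Of the two numbers, compound 1 has the lower one; compound 3 sits higher by a gap beyond the scatter, and compound 2 adds only a limit. The whole series is weak in this assay.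

Compound 4 `Cc1ccc(S(=O)(=O)Oc2c(C(=O)NCc3ccc(F)cc3)nc(Br)c3cccnc23)cc1` differs from compound 1 in one place: ((4-methylphenyl)sulfonyl)oxy in place of (4-aminophenyl)amino on an aromatic carbon. For the measured compounds named here, no measured step of this kind exists, so the expectation rests on the weak level of compound 1 alone. A modest shift toward a higher number, around the scatter or a little beyond, is expected from compound 1 to compound 4, as a 1.6-fold higher number from compound 1 to compound 4 (0.20 log units; within the scatter). Compound 4 is expected at 11000 nM, within 3500 nM to 35000 nM, with a fair chance of only a limit.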

Compound 4, half-maximal inhibitory concentration: > 20000 nM
Compound 4: a limit, no number (the forecaster's own chance of this, stated with the estimate: 40%); middle value at least 1.8-fold (0.25 log units) away from the limit.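

On the aromatic carbon para to a bromo group, ((4-methylphenyl)sulfonyl)oxy in place of (4-aminophenyl)amino in this assay gives an at least 2.8-fold higher number from compound 1 to compound 4 (0.45 log units; beyond the scatter). For the compounds shown here, this is the only one-place step, and it shows that the number at this position responds to the group it carries, by a margin beyond the scatter. The reading for compound 4 is a limit, not a number: the limit of > 20000 nM in this assay, at which 1 of the 4 values shown sits.

As far as these compounds go, whether a piperazine or a methoxy group on this carbon, with the core of compound 1 kept, would give a lower number remains open.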